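The compounds below may be only part of what the source reports. "The series", "measured", "known", "first", "only" and "open" are said of these compounds alone.

Of the compounds shown here, three built on one shared core have been measured in a functional assay on HeLa cells (Homo sapiens) for inhibition, read by sulforhodamine B assay; a higher number here means a weaker inhibitor, a lower number a stronger inhibitor. Compound 1 `O=C1C(Nc2ccccc2F)=CC(=O)c2c1nc1n2[C@H]2OC[C@@H](O)[C@H]2OC1` carries a (2-fluorophenyl)amino group on a double-bonded ring carbon, and in this assay compound 1 gives 9820 nM. Compound 2 `O=C1C=C(N2CCC2)C(=O)c2c1nc1n2[C@H]2OC[C@@H](O)[C@H]2OC1` carries a saturated cyclic amine at that place, and in this assay compound 2 reaches only the limit of > 16000 nM, which is a bound and not a number. Compound 3 `O=C1C(N2CCCCC2)=CC(=O)c2c1nc1n2[C@H]2OC[C@@H](O)[C@H]2OC1` carries piperidin-1-yl, and in this assay compound 3 likewise sits at the limit of > 16000 nM, so only a bound is known for it. The one step that joins two of these compounds at a single place is an at least 1.6-fold higher number from compound 1 to compound 3 (0.21 log units; that floor lies within the scatter), and its true size is hidden by the limit of > 16000 nM in this assay, at which 2 of the 3 values shown sit. Compound 4 `O=C1C(Nc2cccc(Cl)c2)=CC(=O)c2c1nc1n2[C@H]2OC[C@@H](O)[C@H]2OC1` differs from compound 3 as follows: (3-chlorophenyl)amino in place of piperidin-1-yl on a double-bonded ring carbon. This change restores a substituted phenylamino group like that of compound 1, so a lower number is expected for compound 4 because an at least 1.6-fold higher number from compound 1 to compound 3 (0.21 log units; that floor lies within the scatter) ran the other way when the phenylamino group was removed. Compound 4 is therefore expected to give about 9000 nM, with a range from 3500 nM to 20000 nM. The expected step is an at least 1.7-fold lower number from compound 3 to compound 4 (0.24 log units; that floor lies within the scatter).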

Compound 4, half-maximal inhibitory concentration: 7970 nM
Compound 4: the middle estimate sits 1.1-fold (0.05 log units) above what was measured; the range from low to high includes it.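

In this assay, (3-chlorophenyl)amino in place of piperidin-1-yl on a double-bonded ring carbon gives an at least 2.0-fold lower number from compound 3 to compound 4 (0.30 log units; that floor lies within the scatter), so compound 4 joins compound 1 as a second compound with a substituted phenylamino group that returns a number and not a limit, although this floor alone does not clear the scatter. The substituted phenyl group itself makes no readable difference at this place: 3-chlorophenyl in place of 2-fluorophenyl on an amine nitrogen gives a 1.2-fold lower number from compound 1 to compound 4 (0.09 log units; within the scatter), and the two groups cannot be told apart in this assay. The true size of the step to compound 4 stays hidden because compound 3 is known only through a limit: the limit of > 16000 nM in this assay, at which 2 of the 4 values shown sit.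

Still open, from the compounds shown here alone, is whether a phenylamino group with no substituent, or one bearing a methoxy group or a carboxylic acid, would stay in the range of compound 1 and compound 4 or move clearly away from it. Also open, going by these compounds, is whether a saturated amine such as morpholine would give a number and not a limit at this place.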